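Trifluoromethyl in Place of Carbamoyl on the Shared Core

The source may report more compounds than this note shows. Statements on the series, on what has been measured and on what is new or still open speak of the compounds shown alone.

Of the compounds shown here, three have been measured in a physicochemical assay for solubility, with a stated time of 4 h, at pH 2.0; a lower number here means a less soluble compound, a higher number a more soluble compound. Compound 1 `Cc1cc(/C=C/C#N)cc(C)c1Oc1cc(Nc2ccc(C#N)cc2)c(N)cc1C(N)=O` gives 2.09 ug/mL, the second highest of the three numbers. Compound 2 `CC(=O)CCc1cc(C)c(Oc2cc(Nc3ccc(C#N)cc3)c(N)cc2C(F)(F)F)c(C)c1` gives 0.28 ug/mL, a lower number than that of compound 1, and the gap lies beyond the scatter. Compound 3 `COC(=O)c1cc(N)c(Nc2ccc(C#N)cc2)cc1Oc1c(C)cc(CCC#N)cc1C` gives 21.8 ug/mL, a higher number than that of compound 1, and this gap also lies beyond the scatter. Compound 4 `Cc1cc(/C=C/C#N)cc(C)c1Oc1cc(Nc2ccc(C#N)cc2)c(N)cc1C(F)(F)F` awaits measurement in this assay. It differs from compound 1 by trifluoromethyl in place of carbamoyl on an aromatic carbon. Among the measured compounds shown here, no measured pair isolates this change. Compound 2 also carries trifluoromethyl and gives 0.28 ug/mL, so a fall beyond the scatter is expected. The expected step, an 8.4-fold lower number from compound 1 to compound 4 (0.92 log units; beyond the scatter), is downward. Compound 4 is estimated at 0.25 ug/mL, with an expected range from 0.07 ug/mL to 0.9 ug/mL.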

Compound 4, solubility: 0.42 ug/mL
Estimate against measurement, compound 4: 1.7-fold (0.23 log units) below, within the range that was stated.
By their numbers in this assay, from the lowest: compounds 2 and 4 (each within the scatter of the next); then compound 1; then compound 3.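

In this assay, among the compounds shown here, trifluoromethyl in place of carbamoyl on an aromatic carbon brings a 5.0-fold lower number from compound 1 to compound 4 (0.70 log units; beyond the scatter) in the first measured pair that isolates this change at this position. With trifluoromethyl held in place, 2-cyanoethenyl in place of 2-acetylethyl on an aromatic carbon brings a 1.5-fold higher number from compound 2 to compound 4 (0.18 log units; within the scatter) and so does not separate the two compounds. No measurement at hand gives a reason for either step. The compounds shown leave open how a carboxylic acid or an amine would read at this position, and whether trifluoromethyl in place of carbamoyl gives a like step with a longer chain in place of 2-cyanoethenyl.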